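Aryl swap on a saturated ring carbon: compound 3

The compounds below may be only part of what the source reports. "The series", "measured", "known", "first", "only" and "open" are said of these compounds alone.

Measured so far in a functional assay on PPC-1 cells (Homo sapiens) for antiproliferative activity, read by sulforhodamine B assay; a higher number here means a weaker inhibitor, a lower number a stronger inhibitor:
Compound 1, `CCCCCCCCCCCCCCCCCCNC(=O)[C@H]1CSC(CCCCCCCCCCCC)N1`, gives 13000 nM.
Compound 2, `CCCCCCCCCCCCCCCCCCNC(=O)[C@H]1CSC(c2cc(F)cc(F)c2)N1`, gives 10600 nM.

Compound 2 and compound 1 sit within the scatter of each other, the step of a 1.2-fold lower number from compound 1 to compound 2 (0.09 log units; within the scatter) being within it; no order between them is established.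

Compound 3, `CCCCCCCCCCCCCCCCCCNC(=O)[C@H]1CSC(c2ccc(F)c(Br)c2)N1`, differs from compound 2 by 3-bromo-4-fluorophenyl in place of 3,5-difluorophenyl on a saturated ring carbon. For the measured compounds named here, the only measured step at this place, a 1.2-fold lower number from compound 1 to compound 2 (0.09 log units; within the scatter), exchanged a dodecyl chain for an aryl ring and stayed within the scatter. Going by the values given here, no measured step exchanges one aryl ring for another, so there is no guide to the size of this change. Compound 3 is therefore expected to stay close to compound 2, a 1.1-fold lower number from compound 2 to compound 3 (0.03 log units; within the scatter). The estimate for compound 3 is 10000 nM, with a range from 4000 nM to 25000 nM.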

Compound 3, half-maximal inhibitory concentration: 4700 nM
The estimate for compound 3 lay 2.1-fold (0.33 log units) above the measured number, within the range that was stated.
By their numbers in this assay, from the lowest: compound 3; then compounds 2 and 1 (each within the scatter of the next).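

In this assay, for the compounds shown here, replacing 3,5-difluorophenyl with 3-bromo-4-fluorophenyl gives a 2.3-fold lower number from compound 2 to compound 3 (0.35 log units; beyond the scatter), the first step beyond the scatter between two aryl rings at this place. Replacing the dodecyl chain with 3-bromo-4-fluorophenyl gives a 2.8-fold lower number from compound 1 to compound 3 (0.44 log units; beyond the scatter), a separation from the chain that 3,5-difluorophenyl did not show. Nothing available explains either step. Going by these compounds, the halogen set and its arrangement change together in the aryl exchange, and which of them matters stays open. On these data alone, how an aryl ring carrying an amine or a carboxylic acid would read also stays open.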